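Amide-side variations on a shared core, all at the assay limit

The source may hold more compounds than are shown below. What is called first, only, known or untested is meant among the compounds shown, and "the series" means these compounds.

The series keeps the core of compound 1 `CC(C)n1ncc2c(C(=O)NC3CCCC3)cccc21` and varies the group on the amide nitrogen. In a functional assay on MCF7 cells (Homo sapiens) for inhibition, read by MTT assay, with a stated time of 72 h (on this read-out lower numbers stand for stronger inhibition and higher numbers for weaker inhibition), compound 1 gives > 40000 nM, which is a limit of the assay and not a number. Compound 2 `CC(C)n1ncc2c(C(=O)NCc3ccccc3)cccc21` carries a benzyl amide, and in this assay compound 2 gives > 40000 nM, again a limit. The step that the two limits leave unreadable from compound 1 to compound 2 is therefore unreadable. Compound 3 `Cc1ccc(-n2cc(CNC(=O)c3cccc4c3cnn4C(C)C)nn2)cc1` extends the amide substituent further; in this assay compound 3 gives > 40000 nM, a limit as well. Compound 3 thus stands at the limit of > 40000 nM in this assay, at which 3 of the 3 values shown sit, and nothing shown separates it from the other two.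

Compound 4 `CC(C)n1ncc2c(C(=O)NCc3cn(Cc4ccc(C#N)cc4)nn3)cccc21` differs from compound 3 by 4-cyanobenzyl in place of 4-methylphenyl on an aromatic nitrogen. Going by the values given here, no measured step bears on this change: the only step between compounds differing in one place is unreadable, and no compound shows what substitution on that aromatic nitrogen does to the read-out. Among the compounds with values here, the expectation is that compound 4 returns a limit, with a step that the limit leaves unreadable from compound 3 to compound 4 estimated as not separable from no step. Compound 4 is expected at 60000 nM, with the range 20000 nM to 200000 nM.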

Compound 4, half-maximal inhibitory concentration: > 40000 nM
Compound 4 ended at the assay's limit (the forecaster's own chance of this, stated with the estimate: 85%); the middle value does not contradict the limit.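

No step can be read from compound 3 to compound 4, because both stand at a limit of the assay and not at a number: the limit of > 40000 nM in this assay, at which 4 of the 4 values shown sit.

The compounds shown leave open what any amide-side group does to the read-out, and whether any variation on the shared core gives a value inside the range of this assay.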